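A few compounds are considered here, and "the series" means these few. Any claim that something is new, unique, unknown or untested is made for them only; others in the source may bear on it.

Measured compounds:
Compound 1, `COc1ccc(-c2ccc(-c3ccc(C(=N)N)o3)o2)cc1`: 1170 nM
Compound 2, `N=C(N)c1ccc(-c2ccc(-c3cncc4ccccc34)s2)s1`: 880 nM

Both compounds were tested in a functional assay on NCI-H460 cells (Homo sapiens) for inhibition, read by sulforhodamine B assay, with a stated time of 48 h; a higher number here means a weaker inhibitor of growth, a lower number a stronger inhibitor of growth. Compound 1 gives 1170 nM, the highest of the two numbers, and compound 2 gives 880 nM; the gap between them lies within the usual scatter of repeated measurements, so the two cannot be ranked against each other on these numbers.

Compound 3, `N=C(N)c1ccc(-c2ccc(-c3ccccc3)o2)o1`, has not yet been measured. It differs from compound 1 in one place: hydrogen in place of methoxy on an aromatic carbon. The methoxy group sits on the outer six-membered ring of compound 1, and in compound 3 a hydrogen takes its place.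

Going by the values given here, no pair of measured compounds shows the effect of this change, so there is no measured step to lean on. The change removes only two heavy atoms at the edge of the molecule, and the expectation in this assay is a small step, if any, most likely toward a somewhat higher number, that is, a slightly weaker inhibitor of growth. The expected step of a 1.4-fold higher number from compound 1 to compound 3 (0.14 log units; within the scatter) is therefore modest and may fall inside the scatter. For compound 3 the estimated value is 1600 nM, with a range from 600 nM to 4500 nM.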

Compound 3, concentration for 50% growth inhibition: 2450 nM
Estimate against measurement, compound 3: 1.5-fold (0.19 log units) below, within the range that was stated.
By their numbers in this assay, from the lowest: compounds 2 and 1 (each within the scatter of the next); then compound 3.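

Exchanging the methoxy group for hydrogen, para to a large group on the six-membered aromatic ring of carbon only, gives a 2.1-fold higher number from compound 1 to compound 3 (0.32 log units; beyond the scatter) in this assay. Going by these compounds alone, this is the first measured sign that this position is not indifferent to what sits on it: with the methoxy group in place the number is lower, which means stronger inhibition of growth, and with only hydrogen there the compound is a weaker inhibitor, although the step is modest and rests on this single pair. Nothing measured here bears on why the removal of the methoxy group has this effect.

The compounds shown leave open whether the oxygen or the carbon of the methoxy group matters more, and whether a hydroxyl group, an amine, a fluorine atom or a longer chain such as ethoxy at the same position would match compound 1, surpass it or fall back toward compound 3. As far as these compounds go, compound 2 carries no methoxy group and differs from both in more than one place, and whether the same exchange would give a step of similar size on a different core also remains open.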